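Vinyl in place of prop-1-en-1-yl on the amide carbonyl

The compounds below may be only part of what the source reports. "The series", "measured", "known", "first", "only" and "open" are said of these compounds alone.

Compound 1 `CCOC(=O)c1cc(-c2ccc(Oc3ccccc3)cc2)nn1Cc1cccc(NC(=O)CCl)c1` gives 400 nM in a functional assay on JeKo-1 cells (Homo sapiens) for inhibition, read by luminescence and CellTiter-Glo, with a stated time of 72 h; on this read-out higher numbers stand for weaker inhibition and lower numbers for stronger inhibition.
Compound 2 `C/C=C/C(=O)Nc1cccc(Cn2nc(-c3ccc(Oc4ccccc4)cc3)cc2C(=O)OCC)c1` gives 16700 nM in this assay.

Among the compounds with values here, compound 2 thus stands at the higher of the two numbers, its only neighbour being compound 1 with a 42-fold higher number from compound 1 to compound 2 (1.62 log units; beyond the scatter). Compound 3 `C=CC(=O)Nc1cccc(Cn2nc(-c3ccc(Oc4ccccc4)cc3)cc2C(=O)OCC)c1` differs from compound 2 by vinyl in place of prop-1-en-1-yl on a carbonyl carbon. Within the data shown here, the one measured step, a 42-fold higher number from compound 1 to compound 2 (1.62 log units; beyond the scatter), sits at the same carbonyl carbon and is large, so a change there is expected to move the number well beyond the scatter, here toward the lower numbers of compound 1. Compound 3 is therefore estimated at 2000 nM in this assay, within 500 nM to 8000 nM, an expected step of an 8.4-fold lower number from compound 2 to compound 3 (0.92 log units; beyond the scatter).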

Compound 3, half-maximal inhibitory concentration: 7600 nM
Beside the measured number, compound 3's estimate is 3.8-fold (0.58 log units) below it; the measured number falls inside the stated range.
By their numbers in this assay, from the lowest: compound 1; then compound 3; then compound 2.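

In this assay, vinyl in place of prop-1-en-1-yl on the amide carbonyl gives a 2.2-fold lower number from compound 2 to compound 3 (0.34 log units; beyond the scatter), a modest change. Chloromethyl remains well ahead of vinyl, with a 19-fold higher number from compound 1 to compound 3 (1.28 log units; beyond the scatter), so the larger difference at this carbonyl carbon lies between chloromethyl and either alkenyl group, not between the two alkenyl groups. Nothing available accounts for these differences. Still open, as far as these compounds go, is where an ethynyl group, or a longer alkenyl chain ending in a dimethylamine, would fall at this carbonyl carbon.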